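The source may report more compounds than this note shows. Statements on the series, on what has been measured and on what is new or still open speak of the compounds shown alone.

Working notes on the series in a functional assay on the whole organism with Mus musculus as the target, in the maximal electroshock model, with a stated time of 30 min; on this read-out lower numbers stand for an effect already at smaller amounts and higher numbers for an effect only at larger amounts of compound.

Of the compounds shown here, three have been measured so far. Compound 1 `O=C(Nc1ccncc1)Nc1ccccc1Br` gives 100 mg/kg in this assay. Compound 2 `O=C(Nc1ccncc1)Nc1ccccc1F` gives 100 mg/kg. Compound 3 `CC(C)c1ccccc1NC(=O)Nc1ccncc1` gives 100 mg/kg. Compound 3 thus stands level with compounds 1 and 2 on the numbers shown: no change at the digits printed from compound 1 to compound 3 (within the scatter) and no change at the digits printed from compound 2 to compound 3 (within the scatter), and between the other two no change at the digits printed from compound 1 to compound 2 (within the scatter). Every substituent tried so far on that aromatic carbon, bromo, fluoro or isopropyl, has left the minimum effective dose where it was.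

The next compound is compound 4 `O=C(Nc1ccncc1)Nc1ccccc1O`. Its difference from compound 3 is hydroxy in place of isopropyl on an aromatic carbon. Hydroxy brings a hydrogen-bond donor and acceptor that none of the earlier groups carried, so none of the measured steps covers this change directly. What bears on it is only the observation that three unrelated groups at this position gave the same reading, each within the scatter of the others. The expectation is therefore a step of about no change at the digits printed from compound 3 to compound 4 (within the scatter), that is none beyond the scatter, in this assay.

Compound 4 is estimated at 100 mg/kg in this assay, with a range from 50 mg/kg to 300 mg/kg.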

Compound 4, minimum effective dose: > 300 mg/kg
Compound 4 ended at the assay's limit; the forecaster's own chance of this, stated with the estimate: 20%; middle value at least 3.0-fold (0.47 log units) away from the limit.
By their numbers in this assay, from the lowest: compounds 1, 2 and 3 (each within the scatter of the next). At a limit, above all of these: compound 4.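

In this assay, for the compounds shown here, this position proves not to be indifferent to the group it carries: hydroxy is the first group to separate from the others, with an at least 3.0-fold higher number from compound 3 to compound 4 (0.47 log units; beyond the scatter), an at least 3.0-fold higher number from compound 2 to compound 4 (0.47 log units; beyond the scatter) and an at least 3.0-fold higher number from compound 1 to compound 4 (0.47 log units; beyond the scatter). On these data alone, the reading of compound 4 is a limit of the assay and not a number, and the full size of each step stays unknown: the limit of > 300 mg/kg in this assay, at which 1 of the 4 values shown sits. The level readings for bromo, fluoro and isopropyl therefore did not mean that any group is accepted on this aromatic carbon; of the four groups shown, only hydroxy counts a hydrogen-bond donor and a hydrogen-bond acceptor, but a single compound cannot tie the shift to those counts.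

What the compounds shown leave open is whether the shift belongs to hydroxy alone or extends to other groups on this carbon, such as methoxy, an amine or a carboxylic acid. They also leave open whether any group here, a longer chain for instance, can bring the minimum effective dose under the level shared by compounds 1, 2 and 3.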